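The source may hold more compounds than are shown below. What is called first, only, known or untested is meant among the compounds shown, and "the series" means these compounds.

Measured compounds in an assay on isolated protein for activation of Nicotinamide phosphoribosyltransferase (Homo sapiens); on this read-out higher numbers stand for an effect only at larger amounts of compound and lower numbers for an effect already at smaller amounts:
- compound 1 `O=C(NCc1ccncc1)Nc1ccc(S(=O)(=O)c2ccccc2Cl)cc1`: 79 nM
- compound 2 `O=C(NCc1cn[nH]c1)Nc1ccc(S(=O)(=O)c2ccccc2)cc1`: 28 nM
- compound 3 `CCOC(=O)c1ccc(NC(=O)NCc2cc[nH]n2)cc1`: 69000 nM

Of these three numbers, compound 1 holds the second highest. Its nearest neighbour is compound 2, whose number is lower by a margin that lies beyond the usual scatter, while compound 3 sits far above both, with a gap to compound 1 that is also beyond the scatter. Among the compounds with values here, no single-change step between measured compounds is available here, so each pair can only be read from its two values.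

Compound 4 `O=C(NCc1ccncc1)Nc1ccc(S(=O)(=O)NCc2ccccc2)cc1` is derived from compound 1 by a single change: benzylamino in place of 2-chlorophenyl on a sulfonyl sulfur. Compounds 1 and 2 show that the shared core tolerates an aromatic ring on the sulfonyl sulfur well, whereas compound 3, which lacks this part of the molecule and differs elsewhere too, is far weaker. Inserting a benzylamino group in place of the 2-chlorophenyl group keeps an aromatic ring but moves it one atom further out and adds a hydrogen-bond donor. The step from compound 1 to compound 4 is expected to be a moderate loss, a 3.2-fold higher number from compound 1 to compound 4 (0.50 log units; beyond the scatter), though a result within the scatter would not be surprising. Compound 4 is therefore estimated at 250 nM, with a range from 60 nM to 1500 nM.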

Compound 4, half-maximal effective concentration: 102 nM
The estimate for compound 4 lay 2.5-fold (0.39 log units) above the measured number, and the stated range covers the measured number.
By their numbers in this assay, from the lowest: compound 2; then compounds 1 and 4 (each within the scatter of the next); then compound 3.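

In this assay, placing benzylamino instead of 2-chlorophenyl on the sulfonyl sulfur gives a 1.3-fold higher number from compound 1 to compound 4 (0.11 log units; within the scatter), so this read-out does not separate the two compounds. The earlier compounds shown here showed only aromatic rings attached directly to the sulfonyl sulfur. This step adds that the position also accepts benzylamino, which brings a hydrogen-bond donor that 2-chlorophenyl lacks and carries no chlorine, with no change beyond the usual scatter. Nothing measured here accounts for this tolerance.

The compounds shown leave open whether the aromatic ring of benzylamino is needed at all, which a methylamino or morpholine group on the sulfonyl sulfur would test, and whether the hydrogen on its nitrogen matters, which a benzyl(methyl)amino group would test. They also leave open how far this position stretches, for example to the longer phenethylamino chain, or to a benzylamino group whose ring carries a carboxylic acid or the chlorine of compound 1.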